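The source may report more compounds than this note shows. Statements on the series, on what has been measured and on what is new or still open speak of the compounds shown alone.

Measured so far in an ADME assay on MT4 cells (Homo sapiens) for cytotoxicity, read by MTT assay, with a stated time of 5 days; on this read-out higher numbers stand for lower toxicity in this test and lower numbers for higher toxicity in this test:
compound 1, `Cc1cc(C#N)cc(C)c1Oc1nc(NC2CCC(NS(=O)(=O)c3ccc(C#N)cc3)CC2)nc2ccsc12`, 9290 nM
compound 2, `Cc1cc(C#N)cc(C)c1Oc1nc(NC2CCC(NS(=O)(=O)c3ccc(F)cc3)CC2)nc2ccsc12`, 3530 nM

Within the data shown here, compound 2 holds the lowest of the two numbers; the only step that reaches it, a 2.6-fold lower number from compound 1 to compound 2 (0.42 log units; beyond the scatter), lies beyond the scatter. Compound 3, `CC(=O)Nc1ccc(S(=O)(=O)NC2CCC(Nc3nc(Oc4c(C)cc(C#N)cc4C)c4sccc4n3)CC2)cc1`, is not yet measured. It differs from compound 2 by acetamido in place of fluoro on an aromatic carbon. Among the measured compounds shown here, no measured pair carries an acetamido group, so the single step, a 2.6-fold lower number from compound 1 to compound 2 (0.42 log units; beyond the scatter), bears on it only loosely, showing that a change at this aromatic carbon can shift this assay by a modest amount. On that footing a modest rise in the number is expected, roughly a 1.8-fold higher number from compound 2 to compound 3 (0.27 log units; within the scatter), returning toward the value of compound 1. Compound 3 is therefore estimated at 6500 nM, within a range of 2500 nM to 17000 nM.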

Compound 3, half-maximal cytotoxic concentration: 3730 nM
For compound 3 the middle estimate is 1.7-fold (0.24 log units) above the measured one; the measured number falls inside the stated range.
By their numbers in this assay, from the lowest: compounds 2 and 3 (each within the scatter of the next); then compound 1.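

In this assay, acetamido in place of fluoro gives a 1.1-fold higher number from compound 2 to compound 3 (0.02 log units; within the scatter), so a group of four heavy atoms carrying a hydrogen-bond donor and a hydrogen-bond acceptor does not separate from the single fluorine at this aromatic carbon. Measured against the cyano group, acetamido gives a 2.5-fold lower number from compound 1 to compound 3 (0.40 log units; beyond the scatter), close to the step already seen for fluoro, so among these three groups only the cyano of compound 1 stands apart. Nothing available here accounts for this grouping.

The compounds shown leave open whether an amine or a carboxylic acid on this aromatic carbon would fall with compound 2 and compound 3 or with compound 1. They also leave open whether a longer acyl chain in place of the acetyl part of acetamido would stay within the scatter of compound 3.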